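This account rests on a few compounds, and the source may have more. Where it says the series, first, only, none or still open, it means among the compounds named here.

Series notes. Compound 1 `Cc1c(OCCCCOc2ccc(C(=O)O)cc2F)ccc(C(=O)CC(C)C)c1O`, compound 2 `Cc1c(OCCCCOc2ccc(C(=O)O)cc2)ccc(C(=O)CC(C)C)c1O` and compound 3 `Cc1cc(OCCCCOc2ccc(C(=O)CC(C)C)c(O)c2C)ccc1C(=O)O` share one core and differ only on the carboxy-bearing ring. In an assay on HEK293 cells for positive allosteric modulation of metabotropic glutamate receptor 3 (Rattus norvegicus), read by thallium flux, with a stated time of 2.5 min (a lower number here means a smaller maximal response, a higher number a larger maximal response), compound 1 gives 67.7%, compound 2 gives 51.9%, and compound 3 gives 41.9%. Compound 3 stands lowest of the three numbers: compound 2 is nearest and within the scatter of it, compound 1 furthest and beyond the scatter. Compound 4 `Cc1c(OCCCCOc2ccc(C(=O)O)c(Cl)c2)ccc(C(=O)CC(C)C)c1O` is the next variant of compound 3: chloro in place of methyl on an aromatic carbon. Among the measured compounds shown here, two measured steps bear on this change. One is a number 15.8 percentage points lower from compound 1 to compound 2 (beyond the scatter), where removing a halogen from this ring lowered the maximal response; the other is a number 10 percentage points lower from compound 2 to compound 3 (within the scatter), where adding the methyl made no difference beyond the scatter. Putting a halogen back in place of the methyl is therefore expected to raise the number modestly, by a number 13.1 percentage points higher from compound 3 to compound 4 (beyond the scatter) in this assay. The estimate for compound 4 is 55%, within a range from 40% to 72%.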

Compound 4, largest response reached (reported as percent of maximum), in percent of the reference or control that the assay uses: 49.5%
Compound 4: the middle estimate sits 5.5 percentage points above what was measured; the measured number falls inside the stated range.
By their numbers in this assay, from the lowest: compounds 3, 4 and 2 (each within the scatter of the next); then compound 1.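

Chloro ortho to the carboxy group is not told apart from methyl in this assay by a number 7.6 percentage points higher from compound 3 to compound 4 (within the scatter) and is not told apart from hydrogen by a number 2.4 percentage points lower from compound 2 to compound 4 (within the scatter). A halogen on this ring is therefore not enough on its own to reach the level of compound 1: replacing 4-carboxy-2-fluorophenyl with 4-carboxy-3-chlorophenyl gives a number 18.2 percentage points lower from compound 1 to compound 4 (beyond the scatter), a change of both halogen and place that these compounds cannot divide. No measurement at hand accounts for these steps.

Open, going by these compounds, is whether the 4-carboxy-2-chlorophenyl group or a fluoro ortho to the carboxy group would match compound 1, which would part the halogen from its place. A methoxy or trifluoromethyl group ortho to the carboxy group would test whether any group there moves the response beyond the scatter.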